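The compounds below may be only part of what the source reports. "The series", "measured", "known", "first", "only" and "open" are said of these compounds alone.

Measured so far:
- Compound 1 `CCC[S+]([O-])CCCCN=C=S`: 3950 nM
- Compound 2 `CCCC[S+]([O-])CCCCN=C=S`: 2810 nM
- Compound 3 `CC(C)[S+]([O-])CCCCN=C=S`: 3740 nM

These three compounds share one core and differ only in the group on a sulfur. In a functional assay on HCT-116 cells (Homo sapiens) for cytotoxicity, read by MTT assay, with a stated time of 72 h (on this read-out lower numbers stand for stronger inhibition and higher numbers for weaker inhibition), compound 2 gives 2810 nM, a value within the usual scatter of both compound 1 and compound 3. On these numbers, the three cannot be told apart.

The next compound to be tested is compound 4 `[O-][S+](CCCCN=C=S)Cc1ccco1`. Going from compound 2 to compound 4, furan-2-yl takes the place of propyl on a saturated chain carbon bound to a sulfur: furan-2-yl in place of propyl on a saturated chain carbon bound to a sulfur.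

Among the measured compounds shown here, three measured steps bear on this change: a 1.4-fold lower number from compound 1 to compound 2 (0.15 log units; within the scatter), a 1.1-fold lower number from compound 1 to compound 3 (0.02 log units; within the scatter) and a 1.3-fold higher number from compound 2 to compound 3 (0.12 log units; within the scatter). Each one alters the group on the sulfur, and each stays within the scatter. None of them brings in a ring, however, so the data offer no direct measure of what furan-2-yl does here, and the uncertainty must stay wide. With only these small steps as a guide, no change beyond the scatter is expected in this assay.

The expected step is a 1.1-fold higher number from compound 2 to compound 4 (0.03 log units; within the scatter). For compound 4 the estimated value is 3000 nM, with an expected range from 1300 nM to 7000 nM.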

Compound 4, half-maximal inhibitory concentration: 3470 nM
Compound 4: middle estimate off by 1.2-fold (0.06 log units), on the low side; the measured number falls inside the stated range.
By their numbers in this assay, from the lowest: compounds 2, 4, 3 and 1 (each within the scatter of the next).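

Among the compounds shown here, with compound 4, a ring enters this position for the first time: in this assay, furan-2-yl in place of propyl on a saturated chain carbon bound to a sulfur gives a 1.2-fold higher number from compound 2 to compound 4 (0.09 log units; within the scatter), and furan-2-yl in place of ethyl at that carbon gives a 1.1-fold lower number from compound 1 to compound 4 (0.06 log units; within the scatter). The earlier compounds shown here carried only open chains on the sulfur, so they could not show that a five-membered aromatic ring with one hetero atom, which also brings more heavy atoms and a hydrogen-bond acceptor, leaves compound 4 inseparable from them on this read-out. No separate measurement is available to explain this result.

From the compounds shown here alone, all four compounds therefore remain within the scatter of one another, and it stays open whether a phenyl ring, an amine or a carboxylic acid in this position would give a number beyond the scatter. The shown compounds also leave open what a longer or shorter chain in the shared core would do, since that part is the same in all four.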